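A few compounds are considered here, and "the series" means these few. Any claim that something is new, unique, unknown or untested is made for them only; others in the source may bear on it.

Compound 3 `O=C(NNc1nncc2ccccc12)C1CC1c1ccc(OCC(F)(F)F)cc1` gives 17000 nM in a functional assay on OE21 cells (Homo sapiens) for inhibition, read by MTT assay, with a stated time of 72 h (on this read-out lower numbers stand for stronger inhibition and higher numbers for weaker inhibition), and stands lowest of the two numbers reported there; compound 2 `COc1ccc(C2CC2C(=O)NNc2nncc3ccccc23)cc1` gives 48000 nM, and compound 1 `O=C(NNC(=O)C1CC1c1ccc(OC(F)(F)F)cc1)c1ccncc1` gives "not determined" (no result reported), so no result is reported for it. Among the measured compounds shown here, the only measured step, a 2.8-fold lower number from compound 2 to compound 3 (0.45 log units; beyond the scatter), concerns a nearby but different change. Compound 4 `O=C(NNc1nncc2ccccc12)C1CC1c1ccc(OC(F)(F)F)cc1` differs from compound 3 by trifluoromethyl in place of 2,2,2-trifluoroethyl on an oxygen on an aromatic ring. For the measured compounds named here, since that step places trifluoromethyl on a chain carbon rather than shortening the chain, it bears on the present change only loosely, and no step in this set shows what removing one carbon from the ether chain does. The expected step from compound 3 to compound 4 is therefore small, a 1.1-fold lower number from compound 3 to compound 4 (0.05 log units; within the scatter), not beyond the scatter. Compound 4 is estimated at 15000 nM, expected to fall between 5000 nM and 45000 nM.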

Compound 4, half-maximal inhibitory concentration: 42000 nM
Compound 4: middle estimate off by 2.8-fold (0.45 log units), on the low side, within the range that was stated.
By their numbers in this assay, from the lowest: compound 3; then compounds 4 and 2 (each within the scatter of the next).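

In (this assay), the ether on this oxygen is not interchangeable: trifluoromethyl in place of 2,2,2-trifluoroethyl gives (a 2.5-fold higher number from compound 3 to compound 4 (0.39 log units; beyond the scatter)), so the lower number seen with the 2,2,2-trifluoroethyl ether does not carry over to the shorter trifluoromethyl ether. Trifluoromethyl in place of methyl on the same oxygen gives (a 1.1-fold lower number from compound 2 to compound 4 (0.06 log units; within the scatter)), so that exchange alone shows no measurable effect here. Nothing available explains the difference between these ethers. Still open, from the compounds shown here alone, is whether a longer chain such as 3,3,3-trifluoropropyl, or an amine in place of the ether oxygen, would lower the number further.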